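Substituent exchanges on the shared core, compounds 1 to 4

A few compounds are considered here, and "the series" means these few. Any claim that something is new, unique, unknown or untested is made for them only; others in the source may bear on it.

Compound 1 `COc1cc(C=C2C(=O)N(c3ccc(Cl)cc3)N(c3ccc(Cl)cc3)C2=O)ccc1O`: 21800 nM
Compound 2 `COc1cccc(C=C2C(=O)N(c3ccc(Cl)cc3)N(c3ccc(Cl)cc3)C2=O)c1OC`: 29600 nM
Compound 3 `O=C1C(=Cc2ccc(F)cc2F)C(=O)N(c2ccc(Cl)cc2)N1c1ccc(Cl)cc1`: 35700 nM

In a functional assay on MGC-803 cells (Homo sapiens) for cytotoxicity, read by MTT assay, with a stated time of 72 h (a lower number here means a stronger inhibitor, a higher number a weaker inhibitor), compound 3 is not separated from the other two: a 1.2-fold higher number from compound 2 to compound 3 (0.08 log units; within the scatter), and a 1.6-fold higher number from compound 1 to compound 3 (0.21 log units; within the scatter). The remaining pair shows a 1.4-fold higher number from compound 1 to compound 2 (0.13 log units; within the scatter). Compound 4 `O=C1C(=Cc2c[nH]c3ccccc23)C(=O)N(c2ccc(Cl)cc2)N1c1ccc(Cl)cc1` changes the same place: 1H-indol-3-yl in place of 2,4-difluorophenyl on a double-bonded chain carbon bound to a double-bonded ring carbon. Going by the values given here, all three measured steps bear on this change, though no measured compound carries 1H-indol-3-yl, which keeps the range wide. Given a 1.6-fold higher number from compound 1 to compound 3 (0.21 log units; within the scatter), no step beyond the scatter is expected. The expected step is a 1.3-fold lower number from compound 3 to compound 4 (0.11 log units; within the scatter). For compound 4 the estimated value is 28000 nM, with an expected range from 12000 nM to 60000 nM.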

Compound 4, half-maximal inhibitory concentration: 21800 nM
Beside the measured number, compound 4's estimate is 1.3-fold (0.11 log units) above it; low and high end bracket the measured number.
By their numbers in this assay, from the lowest: compounds 1, 4, 2 and 3 (each within the scatter of the next).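

In this assay, 1H-indol-3-yl brings a five-membered aromatic ring with a nitrogen to this place on the double-bonded chain carbon, yet a 1.6-fold lower number from compound 3 to compound 4 (0.21 log units; within the scatter) and a 1.4-fold lower number from compound 2 to compound 4 (0.13 log units; within the scatter) and no change at the digits printed from compound 1 to compound 4 (within the scatter) leave the four compounds unseparated. The place therefore accepts this two-ring group as well as the three substituted phenyl groups, and nothing available accounts for the flat result.

From the compounds shown here alone, whether the read-out needs an aromatic group here stays open, and an amine or a carboxylic acid at this place would test it. Changes elsewhere on the shared core also remain open.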